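The source may report more compounds than this note shows. Statements on the series, on what has been measured and on what is new or still open speak of the compounds shown alone.

Measured so far in an ADME assay for permeability, using PAMPA, with a stated time of 4 h, at pH 7.4, tested at 100 uM; a lower number here means that the compound crosses the layer more slowly, a higher number that the compound crosses the layer faster
Compound 1 `Cc1nc2cc(-c3ccc(OCc4ccccc4)cc3)nn2c(-c2cc(F)c3c(c2C)CCCO3)c1C(OC(C)(C)C)C(=O)O` gives 313 nm/s
Compound 2 `Cc1nc2cc(-c3cccc(OCc4ccccc4)c3)nn2c(-c2cc(F)c3c(c2C)CCCO3)c1C(OC(C)(C)C)C(=O)O` gives 570 nm/s

Compound 2, at 570 nm/s here, lies within the usual scatter of compound 1 at 313 nm/s and the two numbers cannot be told apart. Compound 3 `Cc1nc2cc(-c3cccc(-c4ccccc4)c3)nn2c(-c2cc(F)c3c(c2C)CCCO3)c1C(OC(C)(C)C)C(=O)O` is the next to be measured. It carries phenyl in place of benzyloxy on an aromatic carbon and otherwise keeps the structure of compound 2. Going by the values given here, no two measured compounds differ in one place only, and the data show no step for this change. In this assay no step beyond the scatter is expected, in either direction. The estimate is small, with a 1.1-fold lower number from compound 2 to compound 3 (0.06 log units; within the scatter) expected to stay within the scatter. For compound 3 the estimated value is 500 nm/s with an expected range from 220 nm/s to 1000 nm/s in this measurement.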

Compound 3, apparent permeability: 652 nm/s
Compound 3: middle estimate off by 1.3-fold (0.12 log units), on the low side, within the range that was stated.
By their numbers in this assay, from the lowest: compounds 1, 2 and 3 (each within the scatter of the next, the first and the last beyond it).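

In this assay, putting phenyl in place of benzyloxy on this aromatic carbon, meta to a large group, gives a 1.1-fold higher number from compound 2 to compound 3 (0.06 log units; within the scatter). Going by these compounds alone, this is the first step that can be read at this place, and it shows that a substituent made of carbon only, without the oxygen of benzyloxy and its hydrogen-bond acceptor, gives a number that cannot be told apart from that of compound 2. No measurement shown here explains this result. Going by these compounds, whether an amine or a longer chain on this same aromatic carbon would give a step beyond the scatter remains open. One step at one place also leaves open whether the same exchange would behave alike elsewhere on the molecule.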